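Cytotoxicity in HEL cells: varying the aryl substituent

The compounds below may be only part of what the source reports. "The series", "measured", "known", "first", "only" and "open" are said of these compounds alone.

Measured compounds:
compound 1 `C=Cc1ccc(-c2cc(C)c3ncc(CSCCc4ccccc4)n3c2)cc1` — 14 ug/mL
compound 2 `Cc1cc(-n2ccnc2)cn2c(CSCCc3ccccc3)cnc12` — 23 ug/mL
compound 3 `Cc1cc(C#N)cn2c(CSCCc3ccccc3)cnc12` — 14 ug/mL

Three analogues sharing one core and differing only in the group on the aromatic carbon have been run in an ADME assay on HEL cells (Homo sapiens) for cytotoxicity, with a stated time of 3 days; a lower number here means that less compound is tolerated, a higher number that more compound is tolerated. Compound 1 gives 14 ug/mL in this assay and sits level with its nearest neighbour, compound 3, which gives 14 ug/mL; its furthest neighbour is compound 2 at 23 ug/mL. All three numbers lie within the scatter of one another, so no ordering among them is claimed.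

The next compound, compound 4 `Cc1cc(Sc2ccc(Cl)cc2)cn2c(CSCCc3ccccc3)cnc12`, is not yet measured. Against compound 1 the change is (4-chlorophenyl)sulfanyl in place of 4-vinylphenyl on an aromatic carbon.

Among the measured compounds shown here, the steps that bear on this position are a 1.6-fold higher number from compound 1 to compound 2 (0.22 log units; within the scatter) and no change at the digits printed from compound 1 to compound 3 (within the scatter), with a 1.6-fold lower number from compound 2 to compound 3 (0.22 log units; within the scatter) between the two replacements themselves. Each step at this position stayed within the scatter, whether the entering group was small or ring-bearing. On that basis, in this assay compound 4 is expected to show a 1.1-fold higher number from compound 1 to compound 4 (0.03 log units; within the scatter), that is, no movement beyond the scatter. The estimate for compound 4 is 15 ug/mL, with a range from 7 ug/mL to 32 ug/mL.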

Compound 4, half-maximal cytotoxic concentration: 14 ug/mL
Estimate against measurement, compound 4: 1.1-fold (0.03 log units) above; measured number inside the range.
By their numbers in this assay, from the lowest: compounds 1, 3, 4 and 2 (each within the scatter of the next).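

The (4-chlorophenyl)sulfanyl group brings a sulfur and a chlorine to this aromatic carbon, and in this assay its exchange for 4-vinylphenyl gives no change at the digits printed from compound 1 to compound 4 (within the scatter) with the heavy-atom count and the single six-membered aromatic ring the same on both sides. The same group in place of cyano gives no change at the digits printed from compound 3 to compound 4 (within the scatter) and in place of 1H-imidazol-1-yl gives a 1.6-fold lower number from compound 2 to compound 4 (0.22 log units; within the scatter) so a ring attached through sulfur joins the directly attached groups, and all four compounds now lie within the scatter of one another. No measurement of any property of these groups is available to account for this flat picture.

Going by these compounds, whether a primary amine or a carboxylic acid on this aromatic carbon would also stay within the scatter remains open. Also open, on these data alone, is whether this insensitivity holds in any measurement other than this assay or when the methyl group on the shared core is replaced by a longer chain.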